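The source may report more compounds than this note shows. Statements on the series, on what has been measured and on what is new or still open speak of the compounds shown alone.

Compound 1 is `Cc1ccc(Nc2ncc3c(n2)N(C)C(=O)N(c2cc(NC(=O)c4cccc(C(F)(F)F)c4)ccc2C)C3)cc1`; in an ADME assay on BaF3 cells (Mus musculus) for antiproliferative activity, read by CellTiter-Glo and CCK-8 assay, with a stated time of 72 h (a higher number here means a weaker inhibitor of growth, a lower number a stronger inhibitor of growth), compound 1 gives 8000 nM.
Compound 2 is `CNc1nc(Nc2ccc(C)c([N+](=O)[O-])c2)ncc1C(=O)Nc1cc(NC(=O)c2ccccc2OC)ccc1C`. In this assay compound 2 gives > 10000 nM, which is a limit of the assay and not a number.
Compound 3 is `CNc1nc(Nc2ccc(C)c(N)c2)ncc1C(=O)Nc1cc(NC(=O)c2ccccc2OC)ccc1C`. In this assay compound 3 gives > 10000 nM, again a limit of the assay rather than a measured number.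

So compound 3 stands at the upper edge of what this assay can report, with no number of its own. Going by the values given here, the only measured step that reaches it, a step that the two limits leave unreadable from compound 2 to compound 3, joins two limits and therefore cannot be read in either direction or size; this is the situation described by the limit of > 10000 nM in this assay, at which 2 of the 3 values shown sit. Among the compounds with values here, compound 1 is the only compound with a numeric value, and no single change connects it to compound 3.

Compound 4 is `CNc1nc(Nc2ccc(C)c(N)c2)ncc1C(=O)Nc1cc(NC(=O)c2cc(OC)c(OC)c(OC)c2)ccc1C`. It differs from compound 3 by 3,4,5-trimethoxyphenyl in place of 2-methoxyphenyl on a carbonyl carbon. Within the data shown here, none of the measured steps touches this part of the molecule, so no measured step gives a size for the change. The starting point, compound 3, sits at the limit, and the most likely outcome is that compound 4 is reported at the same limit. Compound 4 is therefore expected at 10000 nM, with a range from 3000 nM to 30000 nM. The expected step of a number no higher from compound 3 to compound 4 (the limit leaves the size open) is estimated to lie within the usual scatter.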

Compound 4, concentration for 50% growth inhibition: > 10000 nM
Compound 4 gave a limit, no number; the forecaster's own chance of this, stated with the estimate: 70%; the middle value lies on the limit itself.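

In this assay compound 4 gives > 10000 nM, which is a limit of the assay and not a number. Compound 3 also stands at a limit, and the step joining compound 3 and compound 4 cannot be read in size or direction. The compounds shown leave open whether 3,4,5-trimethoxyphenyl and 2-methoxyphenyl differ at all in their effect on growth, with the series resting here: the limit of > 10000 nM in this assay, at which 3 of the 4 values shown sit.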